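Methoxy in Place of Ethyl: Compound 3 to Compound 4

This account rests on a few compounds, and the source may have more. Where it says the series, first, only, none or still open, it means among the compounds named here.

Compound 1, `CCc1ccc2nc(C(=O)Nc3c(F)cc(-c4cccc(F)c4)cc3F)c(C)c(O)c2c1`: 0.74%
Compound 2, `Cc1c(C(=O)Nc2ccc(-c3ccccc3)cc2)nc2ccccc2c1O`: 0.23%
Compound 3, `CCc1ccc2nc(C(=O)Nc3c(F)cc(-c4cccc(F)c4)cc3F)c(C)c(C(=O)O)c2c1`: -0.25%

In a functional assay on Hep 3B2 cells (Homo sapiens) for antiproliferative activity, read by MTT assay, with a stated time of 24 h, tested at 0.01 ug/mL (a lower number here means a weaker effect, a higher number a stronger effect of the compound at the concentration tested), all three measured compounds give readings close to zero. Compound 3 has the lowest of the three numbers, but its gap to compound 2 and to compound 1 lies within the scatter, so no order among them can be claimed. Within the data shown here, the one single-point step measured, a number 1 percentage points lower from compound 1 to compound 3 (within the scatter), is likewise within the scatter.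

Compound 4, `COc1ccc2nc(C(=O)Nc3c(F)cc(-c4cccc(F)c4)cc3F)c(C)c(C(=O)O)c2c1`, differs from compound 3 in one place: methoxy in place of ethyl on an aromatic carbon. Among the measured compounds shown here, no measured step touches this position, and the only step known on this core was flat. A step in this assay beyond the scatter is therefore not expected. Compound 4 is estimated at 0.2%, with a range from -5% to 6%, meaning an expected step of a number 0.5 percentage points higher from compound 3 to compound 4 (within the scatter).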

Compound 4, a percentage reported as inhibition, at one concentration (the size of the read-out at that concentration, not a potency): -0.68%
Compound 4: middle estimate off by 0.9 percentage points, on the high side; low and high end bracket the measured number.
By their numbers in this assay, from the lowest: compounds 4, 3, 2 and 1 (each within the scatter of the next).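

Among these compounds, at this position, which no earlier step had touched, methoxy in place of ethyl on an aromatic carbon gives a number 0.4 percentage points lower from compound 3 to compound 4 (within the scatter) in this assay. The swap of one carbon for one oxygen, which brings in one hydrogen-bond acceptor, thus leaves the reading close to zero, as the earlier change on this core did. No measurement offered here bears on the reason for this result. From the compounds shown here alone, whether an amine, a chlorine or a longer chain such as propoxy at this position would move the reading stays open. So does whether methoxy would behave the same with hydroxy in place of the carboxy group.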